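The compounds below may be only part of what the source reports. "The series", "measured", "known", "first", "only" and "open" are said of these compounds alone.

Notes on the series. Compound 1 `CC(=O)N1CCN(c2nnc3nncn3n2)CC1` gives 13100 nM in a functional assay on BeWo cells (Homo sapiens) for inhibition, read by MTT assay, with a stated time of 72 h; on this read-out lower numbers stand for stronger inhibition and higher numbers for weaker inhibition. Compound 2 `CCCCCC(=O)N1CCN(c2nnc3nncn3n2)CC1` gives 2960 nM in this assay. Within the data shown here, the only measured step is a 4.4-fold lower number from compound 1 to compound 2 (0.65 log units; beyond the scatter). Among the measured compounds shown here, on the two numbers so far compound 2 stands lowest, with compound 1 as its nearest neighbour above it.

Compound 3 `CC(C)COC(=O)N1CCN(c2nnc3nncn3n2)CC1` is unmeasured. Against compound 2 it carries isobutoxy in place of pentyl on a carbonyl carbon. The step of a 4.4-fold lower number from compound 1 to compound 2 (0.65 log units; beyond the scatter) bears on this only loosely: there the chain on the carbonyl was extended, whereas here one group is exchanged for another without extension, so no comparable gain is indicated, and no step in either direction beyond the scatter is expected. Compound 3 is therefore expected to give about 4000 nM, with a range from 1500 nM to 12000 nM. The expected step is a 1.4-fold higher number from compound 2 to compound 3 (0.13 log units; within the scatter), leaning slightly toward a higher number.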

Compound 3, half-maximal inhibitory concentration: 13100 nM
Compound 3: the middle estimate sits 3.3-fold (0.52 log units) below what was measured; the measured number lies above the stated range.
By their numbers in this assay, from the lowest: compound 2; then compounds 1 and 3 (each within the scatter of the next).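

At this carbonyl carbon the identity of the group matters and not only its size: isobutoxy enters with as many heavy atoms as the pentyl it replaces, yet in this assay the exchange gives a 4.4-fold higher number from compound 2 to compound 3 (0.65 log units; beyond the scatter). Isobutoxy also offers nothing over methyl on the same carbonyl carbon, with no change at the digits printed from compound 1 to compound 3 (within the scatter), so the gain seen with pentyl does not extend to every larger group at this place. No measured evidence bears on the difference between these groups.

On these data alone, an unbranched butoxy or an isopentyl group on the same carbonyl carbon would help separate the role of the oxygen from that of the branching, and this remains open. As far as these compounds go, whether a hexyl or longer chain would extend the trend from methyl to pentyl also remains open.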